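A few compounds are considered here, and "the series" means these few. Any claim that something is new, unique, unknown or untested is made for them only; others in the source may bear on it.

Of the compounds shown here, three sharing one core have been measured so far in a functional assay on M21 cells (Homo sapiens) for inhibition, read by sulforhodamine B assay, with a stated time of 48 h (on this read-out higher numbers stand for weaker inhibition of growth and lower numbers for stronger inhibition of growth), as a test of growth inhibition. Compound 1 `c1cc2c(cc1NC1=NCCO1)CCC2` gives 8100 nM and compound 2 `c1ccc2cc(NC3=NCCO3)ccc2c1` gives 3500 nM on this scale. Compound 3 `c1cc(C2CCCCC2)ccc1NC1=NCCO1` gives 17800 nM as the highest number of the three, which means the weakest inhibition, and its gaps to both others lie beyond the scatter. Compound 4 `c1ccc(-c2ccc(NC3=NCCO3)cc2)cc1` carries phenyl in place of cyclohexyl on an aromatic carbon and awaits measurement. Going by the values given here, no measured pair shows this swap alone. With compound 3 at 17800 nM at the top of the measured numbers and compound 2 at 3500 nM at the bottom, a modest move toward lower numbers seems likely. The expected step is a 2.7-fold lower number from compound 3 to compound 4 (0.44 log units; beyond the scatter) toward stronger inhibition of growth. For compound 4 the estimate is 6500 nM with an expected range from 2500 nM to 16000 nM once measured.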

Compound 4, concentration for 50% growth inhibition: 8800 nM
The estimate for compound 4 lay 1.4-fold (0.13 log units) below the measured number; measured number inside the range.
By their numbers in this assay, from the lowest: compound 2; then compounds 1 and 4 (each within the scatter of the next); then compound 3.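

Going by these compounds alone, the first comparison that changes one place shows that the number at this position depends on the kind of ring and not only on its size: in this assay phenyl in place of cyclohexyl gives a 2.0-fold lower number from compound 3 to compound 4 (0.31 log units; beyond the scatter) and so a modest gain in inhibition of growth. Both groups have the same count of heavy atoms, and one ring is aromatic while the other is not. On these data alone, how an amine, a carboxylic acid or a longer chain at this position would compare remains open. Nothing available explains why the aromatic ring gives the lower number.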